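The source may report more compounds than this note shows. Statements on the series, on what has been measured and on what is new or still open speak of the compounds shown alone.

Within the data shown here, in a functional assay on MCF7 cells (Homo sapiens) for antiproliferative activity, read by WST assay, with a stated time of 5 days (on this read-out higher numbers stand for weaker inhibition and lower numbers for stronger inhibition), compound 1 `COc1cc(O)c2c(c1O)C/C(CO)=C\CC[C@@]1(C)O[C@@H]1C2=O` gives 43000 nM, and compound 2 `COc1cc(O)c2c(c1O)C/C(C(OC(C)=O)OC(C)=O)=C\CC[C@@]1(C)O[C@@H]1C2=O` gives 5600 nM, the lower of the two numbers so far. Compound 3 `COc1cc(O)c2c(c1O)C/C(CBr)=C\CC[C@@]1(C)O[C@@H]1C2=O` carries bromomethyl in place of diacetoxymethyl on a double-bonded ring carbon. Among the measured compounds shown here, the only measured step at this place is a 7.7-fold lower number from compound 1 to compound 2 (0.89 log units; beyond the scatter), and it involves no bromomethyl, so it gives only a rough size and no firm direction. In this assay, a step no larger than that is expected, leaning slightly lower. The expected step is a 1.4-fold lower number from compound 2 to compound 3 (0.15 log units; within the scatter). Compound 3 is estimated at 4000 nM, within a range of 800 nM to 20000 nM.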

Compound 3, half-maximal inhibitory concentration: 32000 nM
Estimate against measurement, compound 3: 8.0-fold (0.90 log units) below, and the stated range ends below it.
By their numbers in this assay, from the lowest: compound 2; then compounds 3 and 1 (each within the scatter of the next).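

In this assay, the lower number seen with diacetoxymethyl does not carry over to bromomethyl, with a 5.7-fold higher number from compound 2 to compound 3 (0.76 log units; beyond the scatter). Bromo in place of hydroxy on the saturated chain carbon gives a 1.3-fold lower number from compound 1 to compound 3 (0.13 log units; within the scatter), so these two cannot be told apart, and of the three only compound 2 stands clear of the others. No available evidence accounts for this difference. The compounds shown leave open whether an aminomethyl or carboxylic acid group on the double-bonded ring carbon would fall with compound 3 or with compound 2. They also leave open how a single acetoxymethyl group would compare.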